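This account rests on a few compounds, and the source may have more. Where it says the series, first, only, none or still open, it means among the compounds named here.

Compound 1 `COc1ccc(/C=C\C(=O)N2N=C(c3ccncc3)OC2c2c[nH]c3ccccc23)cc1` is studied in an ADME assay on PANC-1 cells (Homo sapiens) for cytotoxicity, read by MTT assay, with a stated time of 48 h; on this read-out higher numbers stand for weaker inhibition of growth and lower numbers for stronger inhibition of growth. In this assay compound 1 gives only a limit, > 30 ug/mL. Compound 2 `O=C(/C=C\c1cccc(Cl)c1Cl)N1N=C(c2ccncc2)OC1c1c[nH]c2ccccc12` carries 2,3-dichlorophenyl in place of 4-methoxyphenyl on a double-bonded chain carbon bound to a double-bonded chain carbon. In this assay compound 2 likewise gives only a limit, > 30 ug/mL. The step that the two limits leave unreadable from compound 1 to compound 2 therefore has no readable size, because of the limit of > 30 ug/mL in this assay, at which 2 of the 2 values shown sit.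

Within the data shown here, compound 3 `O=C(/C=C\c1cccc(Br)c1)N1N=C(c2ccncc2)OC1c1c[nH]c2ccccc12` differs from compound 1 as follows: 3-bromophenyl in place of 4-methoxyphenyl on a double-bonded chain carbon bound to a double-bonded chain carbon The only measured step that touches this part of the molecule is the one just described, and its size cannot be read, so no direction or size of change in this assay can be foreseen beyond the scatter. On that basis compound 3 is expected to give about 40 ug/mL, with a likely range from 15 ug/mL to 120 ug/mL, and most probably again only a limit. The step that the limit leaves unreadable from compound 1 to compound 3 is accordingly estimated to be small.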

Compound 3, concentration for 50% growth inhibition: > 30 ug/mL
Compound 3 ended at the assay's limit; the forecaster's own chance of this, stated with the estimate: 75%; the middle value is on the limit's open side.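

No step can be read among compound 1, compound 2 and compound 3 in this assay, because each gives only a limit: the limit of > 30 ug/mL in this assay, at which 3 of the 3 values shown sit. These compounds leave open whether 4-methoxyphenyl, 2,3-dichlorophenyl and 3-bromophenyl differ at all in their effect on growth inhibition.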